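Methoxy addition on the pyrazole aryl of compound 1

A few compounds are considered here, and "the series" means these few. Any claim that something is new, unique, unknown or untested is made for them only; others in the source may bear on it.

Compound 1 `COc1ccc(-c2cc(/C=C/C(=O)c3ccc(N)cc3)[nH]n2)cc1` stands highest of the two numbers measured in a functional assay on OVCAR-4 cells (Homo sapiens) for inhibition, read by sulforhodamine B assay, with a stated time of 48 h (a higher number here means that more compound is tolerated, a lower number that less compound is tolerated), where compound 1 gives 51200 nM. Nearest is compound 2 `COc1ccc(C(=O)/C=C/c2cc(-c3cc(OC)c(OC)c(OC)c3)n[nH]2)cc1OC`, which in this assay gives 49900 nM, a difference that lies within the scatter, so no order between them is claimed. For compound 3 `COc1ccc(C(=O)/C=C/c2cc(-c3cc(OC)c(OC)c(OC)c3)n[nH]2)cc1` the this assay reports only a limit, > 100000 nM. Going by the values given here, the one measured step that bears on the planned change is an at least 2.0-fold higher number from compound 2 to compound 3 (0.30 log units; that floor lies within the scatter), and its size is known only as a floor because of the limit of > 100000 nM in this assay, at which 1 of the 3 values shown sits.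

Compound 4 `COc1ccc(-c2cc(/C=C/C(=O)c3ccc(N)cc3)[nH]n2)cc1OC` differs from compound 1 by methoxy in place of hydrogen on an aromatic carbon. This is the opposite direction to the change from compound 2 to compound 3, though on a different six-membered ring of the shared core. If the effect carries over, adding the methoxy should give a somewhat lower number in this assay, but the measured step itself does not clear the scatter with certainty, so no more than a modest shift is expected.

Compound 4 is therefore expected to give about 35000 nM in this assay, with a likely range from 15000 nM to 90000 nM. That expectation amounts to a step of a 1.5-fold lower number from compound 1 to compound 4 (0.17 log units; within the scatter), small enough that it may be read as none beyond the scatter.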

Compound 4, concentration lethal to 50% of the cells: 40500 nM
For compound 4 the middle estimate is 1.2-fold (0.06 log units) below the measured one; the range from low to high includes it.
By their numbers in this assay, from the lowest: compounds 4, 2 and 1 (each within the scatter of the next). At a limit, above all of these: compound 3.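

In this assay, methoxy in place of hydrogen on an aromatic carbon, ortho to a methoxy group and meta to a large group, gives a 1.3-fold lower number from compound 1 to compound 4 (0.10 log units; within the scatter), so at this position the added methoxy produces no shift that can be told from the scatter. Before this result, the change had been seen only on a different six-membered ring, where its size was known only as a floor, whereas on the core of compound 1 it now has a size that can be read in full. The two readings of the same change can be set side by side, but no difference between them can be claimed: the same change on two cores in this assay, an at least 2.0-fold higher number (0.30 log units; that floor lies within the scatter) from compound 2 to compound 3 and a 1.3-fold higher number (0.10 log units; within the scatter) from compound 4 to compound 1; the limit leaves it open whether they differ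

The compounds shown leave open whether a group other than methoxy on this aromatic carbon, such as hydroxy or ethoxy, would move the number beyond the scatter. They also leave open whether the methoxy change would read the same with a carboxylic acid in place of the amine that compound 1 and compound 4 share.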